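Ring size at the chain carbon: compound 3 to compound 4

The source may hold more compounds than are shown below. What is called first, only, known or untested is meant among the compounds shown, and "the series" means these compounds.

Measured in an ADME assay on microsomes from liver (Mus musculus, strain NMRI) for metabolic stability, tested at 2.5 uM; a higher number here means faster removal of the compound, a lower number slower removal:
- compound 1, `Fc1cc(Cl)ccc1-c1ccc(Cn2nnc3ccccc32)nc1`: 1.6 mL/min/g
- compound 2, `Brc1ccc(Cn2nnc3c(Br)cccc32)nc1`: 1.1 mL/min/g
- compound 3, `Brc1cccc2c1nnn2CC1CCCC1`: 11.4 mL/min/g

Compound 3 stands highest of the three numbers in this assay. Compound 1 sits nearest, and compound 2 furthest; both of those gaps lie beyond the scatter, so compound 3 is cleared fastest among the compounds measured here. For the measured compounds named here, no pair of measured compounds differs in a single place, so no single-change step has been observed in this set, and only the three values themselves are known.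

Compound 4, `Brc1cccc2c1nnn2CC1CCC1`, has not yet been measured. It differs from compound 3 in one place: cyclobutyl in place of cyclopentyl on a saturated chain carbon bound to an aromatic nitrogen. The shared core is kept; only the ring on the saturated chain carbon bound to the aromatic nitrogen shrinks by one carbon.

Going by the values given here, with no measured step of this kind to lean on, the step of a 1.3-fold lower number from compound 3 to compound 4 (0.13 log units; within the scatter) is expected to be small, at most a modest lowering, likely within the scatter. Compound 4 is estimated at 8.5 mL/min/g, with a range from 4 mL/min/g to 16 mL/min/g.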

Compound 4, intrinsic clearance in a liver preparation (reported as CLH), per the amount of preparation that the assay uses: 11.4 mL/min/g
Compound 4: the middle estimate sits 1.3-fold (0.13 log units) below what was measured, within the range that was stated.
By their numbers in this assay, from the lowest: compounds 2 and 1 (each within the scatter of the next); then compounds 3 and 4 (each within the scatter of the next).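

In this assay the series now has its first step that changes a single place, and it reads no change at the digits printed from compound 3 to compound 4 (within the scatter). On a saturated chain carbon bound to an aromatic nitrogen, cyclobutyl in place of cyclopentyl therefore leaves the number unmoved, so removing one ring carbon at this position makes no readable difference on this core. Nothing available explains why the number holds.

Still open, from the compounds shown here alone, is whether an open chain such as isobutyl, or an amine or a carboxylic acid carried on the same chain carbon, would move the number at this position. This step also cannot show whether the same ring change would behave alike on a core other than the one shared by these two compounds.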